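Adding 3-methoxyphenyl to compound 2

The source may hold more compounds than are shown below. What is called first, only, known or untested is meant among the compounds shown, and "the series" means these compounds.

Measured in a functional assay on HCT-116 cells (Homo sapiens) for antiproliferative activity, read by MTT assay, with a stated time of 72 h; on this read-out lower numbers stand for stronger inhibition and higher numbers for weaker inhibition:
- Compound 1 `O=C1COc2ccc(-c3cnc(Cl)c(NS(=O)(=O)c4ccc(F)cc4)c3)cc2N1C1CCCCC1` gives > 40000 nM (a limit)
- Compound 2 `O=C1COc2ccc(-c3cccc(NS(=O)(=O)c4ccc(F)cc4)c3)cc2N1` gives > 40000 nM (a limit)
- Compound 3 `CC(C)N1C(=O)COc2ccc(-c3cnc(Cl)c(NS(=O)(=O)c4ccc(F)cc4)c3)cc21` gives 18900 nM (a number)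

Compound 2 gives > 40000 nM and this is a limit of the assay, not a number. Compound 1 also stands at a limit, so compound 3 is the only one of the three with a true number.

Compound 4 `COc1cccc(N2C(=O)COc3ccc(-c4cccc(NS(=O)(=O)c5ccc(F)cc5)c4)cc32)c1` differs from compound 2 in one place: 3-methoxyphenyl in place of hydrogen on an amide-type nitrogen in a ring and nothing else changes.

Among the measured compounds shown here, only one measured step touches that nitrogen: an at least 2.1-fold lower number from compound 1 to compound 3 (0.32 log units; beyond the scatter) with isopropyl in place of cyclohexyl. That step is modest, it swaps one group for another rather than replacing hydrogen, and the core of compound 1 is not the core of compound 2. So it offers only a weak guide. A further caution is the limit of > 40000 nM in this assay, at which 2 of the 3 values shown sit, and compound 4 may well stay at that limit too.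

A modest move towards stronger inhibition in this assay is the most that can be expected. The estimated step is an at least 1.6-fold lower number from compound 2 to compound 4 (0.20 log units; that floor lies within the scatter) and it is uncertain in size. Compound 4 is therefore expected at 25000 nM with an estimated range from 8000 nM to 40000 nM on this read-out.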

Compound 4, half-maximal inhibitory concentration: > 40000 nM
Compound 4 gave a limit, no number (the forecaster's own chance of this, stated with the estimate: 50%); at least 1.6-fold (0.20 log units) between middle value and limit.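

In this assay compound 4 gives > 40000 nM, a limit and not a number. Among the compounds shown here, compound 2 gives > 40000 nM, also a limit, so no step from compound 2 to compound 4 can be read: the limit of > 40000 nM in this assay, at which 3 of the 4 values shown sit. The compounds shown leave open whether 3-methoxyphenyl in place of hydrogen on that amide-type nitrogen changes the inhibition at all.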